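Aryl exchange on the shared core: toward compound 4

The source may hold more compounds than are shown below. What is called first, only, known or untested is meant among the compounds shown, and "the series" means these compounds.

In a physicochemical assay for lipophilicity (on this read-out higher numbers stand for higher lipophilicity and lower numbers for lower lipophilicity), compound 1 `C[C@H]1CC[C@@H]2[C@@H](OC(=O)[C@]23CC(c2ccc(N(C)C)cc2)=NO3)[C@]2(C)C(=O)C=C[C@@]12O` gives 1.51, compound 2 `C[C@H]1CC[C@@H]2[C@@H](OC(=O)[C@]23CC(c2ccc(O)cc2)=NO3)[C@]2(C)C(=O)C=C[C@@]12O` gives 0.932 and compound 3 `C[C@H]1CC[C@@H]2[C@@H](OC(=O)[C@]23CC(c2ccc([N+](=O)[O-])cc2)=NO3)[C@]2(C)C(=O)C=C[C@@]12O` gives 1.37. Compound 3 stands level with compound 1 and apart from compound 2: a number 0.14 log units lower from compound 1 to compound 3 (within the scatter), and a number 0.44 log units higher from compound 2 to compound 3 (beyond the scatter). Compound 4 `Cc1cccc(C2=NO[C@]3(C2)C(=O)O[C@@H]2[C@H]3CC[C@H](C)[C@]3(O)C=CC(=O)[C@@]23C)c1` carries 3-methylphenyl in place of 4-nitrophenyl on a carbon with a double bond to nitrogen, that is, 3-methylphenyl in place of 4-nitrophenyl on a carbon with a double bond to nitrogen. The measured steps each exchange one group on an aromatic carbon, and one of them is a number 0.58 log units lower from compound 1 to compound 2 (beyond the scatter). None brings in methyl, so they guide the size only loosely and the direction remains a judgement. A modest rise in this assay is expected, the estimated change being a number 0.48 log units higher from compound 3 to compound 4 (beyond the scatter). Compound 4 is estimated at 1.85, with an expected range of 1.45 to 2.25.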

Compound 4, partition coefficient: 1.86
For compound 4 the middle estimate is 0.01 log units below the measured one, and the stated range covers the measured number.
By their numbers in this assay, from the lowest: compound 2; then compounds 3 and 1 (each within the scatter of the next); then compound 4.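

In this assay, replacing the aryl group on the carbon with a double bond to nitrogen gives a step beyond the scatter in all three new pairs, with a number 0.49 log units higher from compound 3 to compound 4 (beyond the scatter) and a number 0.93 log units higher from compound 2 to compound 4 (beyond the scatter) and also a number 0.35 log units higher from compound 1 to compound 4 (beyond the scatter) at this position. Compound 4 is now the highest of the four, and 3-methylphenyl differs from each earlier aryl group in both its substituent and that substituent's ring place, so these steps do not separate the two. No measurement shown explains these steps. As far as these compounds go, how a carboxylic acid or a longer chain on this aromatic ring would read in this assay remains open.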